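A few compounds are considered here, and "the series" means these few. Any claim that something is new, unique, unknown or untested is made for them only; others in the source may bear on it.

Measured so far:
Compound 1, `CCCNC(=O)Nc1ccc2c(c1)COC2=O`: in a functional assay on cells (T-cell, Mus musculus) for inhibition (a higher number here means a weaker inhibitor, a lower number a stronger inhibitor), compound 1 gives 58100 nM.
Compound 2, `O=C(Nc1ccccc1)C(=O)Nc1ccc2c(c1)COC2=O`: in this assay compound 2 gives 36100 nM.

Compound 2 has the lower of the two numbers, but its nearest neighbour, compound 1, sits only a little above it, and that gap lies within the scatter of this assay, so the two cannot be ranked against each other on what is shown. Both share the same core and differ in the group on the other side of the urea or oxalamide linker.

The next compound, compound 3, `Cc1ccccc1NC(=O)C(=O)Nc1ccc2c(c1)COC2=O`, is compound 2 with one change: methyl in place of hydrogen on an aromatic carbon. Read one bond further out, the change is phenyl to 2-methylphenyl. Within the data shown here, no step between two measured compounds of this set shows what a methyl on that ring does, so the expectation rests on the change being one carbon only. Compound 3 is expected to come out close to compound 2, with a step of a 1.4-fold lower number from compound 2 to compound 3 (0.14 log units; within the scatter) in this assay, which is no more than the scatter allows. Compound 3 is therefore estimated at 26000 nM, with a range from 8000 nM to 80000 nM.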

Compound 3, half-maximal inhibitory concentration: 5510 nM
For compound 3 the middle estimate is 4.7-fold (0.67 log units) above the measured one; measured number below the stated range.
By their numbers in this assay, from the lowest: compound 3; then compounds 2 and 1 (each within the scatter of the next).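

In this assay, a single methyl placed on an aromatic carbon of the six-membered ring, ortho to a large group, gives a 6.6-fold lower number from compound 2 to compound 3 (0.82 log units; beyond the scatter). Among these compounds, this is the only step between measured compounds in the set, and it shows that this place on the phenyl ring is not indifferent: the change of phenyl to 2-methylphenyl adds one carbon, with no ring and no charge, and still moves the number beyond the scatter. Nothing available here bears on why this methyl has such an effect.

The compounds shown hold only hydrogen or methyl at this place, so it remains open whether the drop in the number belongs to methyl alone or would also come with an ethyl, a chlorine or a methoxy on the same carbon. Also open, from the compounds shown here alone, are whether a methyl on another carbon of that ring would give a step of similar size, and whether a second methyl on the ring would add to the first.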